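Thiophene to Hydroxyphenyl on the Carbonyl: a Writhing-Test Step

The compounds below may be only part of what the source reports. "The series", "measured", "known", "first", "only" and "open" are said of these compounds alone.

Compound 1 `O=C(/N=C1\NC2(CCCCO2)CCS1)c1cccc(F)c1`: 9.2 mg/kg
Compound 2 `O=C(/N=C1\NC2(CCCCO2)CCS1)c1cccs1`: 48 mg/kg

Both compounds share one core and differ only in the ring attached to the carbonyl carbon. In a functional assay on the whole organism (strain CF-1) with Mus musculus as the target, in the writhing test, with a stated time of 15 min (a lower number here means that less compound is needed, a higher number that more compound is needed for the effect), compound 1 gives 9.2 mg/kg, while compound 2 gives 48 mg/kg, the higher of the two numbers. For the measured compounds named here, the one recorded step, a 5.2-fold higher number from compound 1 to compound 2 (0.72 log units; beyond the scatter), shows that putting thiophen-2-yl in place of 3-fluorophenyl raised the number. Compound 3 `O=C(/N=C1\NC2(CCCCO2)CCS1)c1ccccc1O` has not yet been tested. It differs from compound 2 by 2-hydroxyphenyl in place of thiophen-2-yl on a carbonyl carbon. Going by the values given here, only the step from compound 1 to compound 2 bears on this change, and only partly, since it concerns a different six-membered aromatic ring of carbon only; it suggests that returning to such a ring should lower the number, but no measured compound carries a 2-hydroxyphenyl. A modest lowering is therefore expected, a 2.7-fold lower number from compound 2 to compound 3 (0.43 log units; beyond the scatter). Compound 3 is estimated at 18 mg/kg, within a range from 6 mg/kg to 55 mg/kg.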

Compound 3, dose for half-maximal effect: > 200 mg/kg
Compound 3 was reported as a limit (the forecaster's own chance of this, stated with the estimate: 10%); middle value at least 11-fold (1.04 log units) from the limit.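

In this assay compound 3 gives a limit of the assay and not a number: the limit of > 200 mg/kg in this assay, at which 1 of the 3 values shown sits. A six-membered aromatic ring of carbon only on the carbonyl carbon does not by itself keep the number low: the change to 2-hydroxyphenyl gives an at least 4.1-fold higher number from compound 2 to compound 3 (0.61 log units; beyond the scatter), and the comparison with 3-fluorophenyl gives an at least 21-fold higher number from compound 1 to compound 3 (1.33 log units; beyond the scatter). This position therefore separates two rings of the same kind, so the ring type alone does not set the number.

On these data alone, how far compound 3 lies past its limit stays unknown, so both steps have only a lower bound. Plain phenyl and 3-hydroxyphenyl are not among the compounds shown, which leaves open whether the rise follows the hydroxyl group itself or its place on the ring, and how a methoxy group or an amine would behave there.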